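From a phenoxyacetamide to a cyanophenyl sulfonamide

The source may hold more compounds than are shown below. What is called first, only, known or untested is meant among the compounds shown, and "the series" means these compounds.

Two compounds have so far been run in an ADME assay on microsomes from liver (Homo sapiens) for metabolic stability, read by LC-MS, with NADPH named in the record, with a stated time of 60 min, tested at 1 uM, in the absence of a further agent; on this read-out higher numbers stand for a more stable compound and lower numbers for a less stable compound. Compound 1 `CC(=O)N[C@@H]1CCN(c2cc(C)nn3c(-c4ccc(C(F)(F)F)cc4)c(C)nc23)C1` sits at a limit of the assay rather than at a number: in this assay compound 1 gives > 95%. Compound 2 `COc1ccc(-c2c(C)nc3c(N4CC[C@@H](NC(=O)COc5ccccc5)C4)cc(C)nn23)cc1OC` likewise sits at a limit and not at a number: in this assay compound 2 gives > 95%. Among the compounds with values here, no step between the measured compounds can be sized, since (the limit of > 95% in this assay, at which 2 of the 2 values shown sit). Compound 3 `COc1ccc(-c2c(C)nc3c(N4CC[C@@H](NS(=O)(=O)c5ccc(C#N)cc5)C4)cc(C)nn23)cc1OC` has not yet been measured in this assay. It differs from compound 2 by (4-cyanophenyl)sulfonyl in place of (phenoxymethyl)carbonyl on an amine nitrogen. With both measured values resting at a limit, no direction can be read from them. The step from compound 2 to compound 3 is expected to be a number at least 7 percentage points lower from compound 2 to compound 3 (that floor lies within the scatter), an estimated change of no more than the scatter, or a little below it. Compound 3 is accordingly expected to give 88% in this assay, within an estimated range from 70% to 100%.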

Compound 3, percent of the compound remaining: > 95%
Compound 3: only a limit was reported (the forecaster's own chance of this, stated with the estimate: 55%); at least 7 percentage points between middle value and limit.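

In this assay, no step from compound 2 to compound 3 can be read, since both compounds rest at a limit and not at a number: the limit of > 95% in this assay, at which 3 of the 3 values shown sit.

The compounds shown leave open whether (4-cyanophenyl)sulfonyl and (phenoxymethyl)carbonyl differ at all on this read-out.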